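This account rests on a few compounds, and the source may have more. Where it says the series, first, only, none or still open, it means among the compounds named here.

In a functional assay on MCF7 cells (Homo sapiens) for antiproliferative activity, read by WST assay, with a stated time of 72 h (on this read-out lower numbers stand for stronger inhibition and higher numbers for weaker inhibition), compound 1 `Clc1ccc2[nH]c(-c3nc(-c4ccccc4)no3)cc2c1` gives 29100 nM. Compound 2 `Fc1ccc2[nH]c(-c3nc(-c4ccc(Cl)cc4)no3)cc2c1` shares the core and carries a fluoro on the fused ring system together with a chloro on the phenyl ring. In this assay compound 2 reaches only the limit of > 50000 nM, which is a limit of the assay and not a number. Of the two values shown, compound 2 therefore stands at the upper edge, a position described by the limit of > 50000 nM in this assay, at which 1 of the 2 values shown sits. Compound 3 `Clc1ccc(-c2noc(-c3cc4cc(Cl)ccc4[nH]3)n2)cc1`, not yet measured, differs from compound 2 by chloro in place of fluoro on an aromatic carbon of the six-membered aromatic ring of carbon only, within the fused system of two rings. No measured step of this kind is at hand, so the expectation rests on what is shown. Compound 3 is expected to remain weak, with a step of an at least 1.2-fold lower number from compound 2 to compound 3 (0.09 log units; that floor lies within the scatter) that is estimated as small and within the scatter. For compound 3 an estimate of 40000 nM, ranging from 15000 nM to 100000 nM, is expected in this assay.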

Compound 3, half-maximal inhibitory concentration: > 50000 nM
Compound 3: only a limit was reported; the forecaster's own chance of this, stated with the estimate: 45%; middle value at least 1.2-fold (0.09 log units) from the limit.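

In this assay, among the compounds shown here, compound 3 offers the first comparison between compounds that differ in one place, a chloro on the phenyl ring where compound 1 carries none: an at least 1.7-fold higher number from compound 1 to compound 3 (0.23 log units; that floor lies within the scatter). For compound 3 the value of > 50000 nM is a limit of the assay and not a number, so only a floor is known for this step. The step for chloro in place of fluoro on the six-membered aromatic ring of carbon only cannot be read, and compound 3 joins compound 2 at the upper edge: the limit of > 50000 nM in this assay, at which 2 of the 3 values shown sit.

Going by these compounds, how far the chloro on the phenyl ring raises the number remains open, since the step has no upper bound. Also open, on these data alone, is whether an amine or a carboxylic acid in its place would give a readable value on the shared core.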